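The compounds below may be only part of what the source reports. "The series", "measured", "known", "first", "only" and "open" are said of these compounds alone.

Working notes on the series. The shared core of compound 1 `OCc1ccc(-c2ccc3c(O)cccc3c2)cc1` carries a hydroxymethyl on the distal aromatic ring, and in an assay for binding affinity to 17-beta-hydroxysteroid dehydrogenase type 2 (Homo sapiens), with a stated time of 20 min, tested at 1 uM (on this read-out higher numbers stand for more inhibition at the one concentration tested (going by the name of the read-out) and lower numbers for less inhibition), compound 1 gives 31%. Compound 2 `CC(=O)c1ccc(-c2ccc3c(O)cccc3c2)cc1` has an acetyl in its place. In this assay compound 2 reaches only the limit of the read-out, < 10%, and no number is reported for it; it is one of the values that sit at the limit of < 10% in this assay, at which 1 of the 2 values shown sits. The change from compound 1 to compound 2, acetyl in place of hydroxymethyl on an aromatic carbon, gave a number at least 21 percentage points lower from compound 1 to compound 2 (beyond the scatter).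

Compound 3 `CNC(=O)c1ccc(-c2ccc3c(O)cccc3c2)cc1` is not yet measured. It differs from compound 2 by methylamino in place of methyl on a carbonyl carbon, so acetyl becomes methylcarbamoyl. Going by the values given here, no measured step covers this exchange on the carbonyl carbon; the only step known, from compound 1 to compound 2, concerns the group on the aromatic carbon and is at least modest in size. With compound 2 at the limit, compound 3 can only be expected to stay near the limit or rise a little; the estimated step is a number at least 5 percentage points higher from compound 2 to compound 3 (that floor lies within the scatter). Compound 3 is therefore expected at about 15%, within 5% to 35%.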

Compound 3, a percentage reported as inhibition, at one concentration (the size of the read-out at that concentration, not a potency): 13%
Compound 3: the middle estimate sits 2 percentage points above what was measured; low and high end bracket the measured number.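

Methylamino in place of methyl on a carbonyl carbon is the first change read at this carbonyl, and it gives a number at least 3 percentage points higher from compound 2 to compound 3 (that floor lies within the scatter) in this assay. From the compounds shown here alone, compound 2 stands at < 10%, which is a limit and not a number, so this step is only a floor and its true size stays unknown: the limit of < 10% in this assay, at which 1 of the 3 values shown sits. Going by these compounds alone, the comparison with a full number on both sides is a number 18 percentage points lower from compound 1 to compound 3 (beyond the scatter), which shows that acetyl is not the only carbonyl-bearing group on this aromatic carbon to stand lower than hydroxymethyl, since methylcarbamoyl does as well.

The compounds shown do not tell whether a carboxylic acid or an aminomethyl group on the same aromatic carbon would stay at the level of the two carbonyl compounds or return to that of hydroxymethyl. They also leave open whether the amide hydrogen of methylcarbamoyl has any part in the reading, a question that dimethylamino on the carbonyl carbon would address, and whether a longer chain such as hydroxyethyl would hold the value of compound 1.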